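The source may hold more compounds than are shown below. What is called first, only, known or untested is meant among the compounds shown, and "the series" means these compounds.

Measured in a functional assay on A549 cells (Homo sapiens) for cytotoxicity, read by MTT assay, with a stated time of 72 h; a higher number here means a weaker inhibitor, a lower number a stronger inhibitor:
- Compound 1 `CNC(=O)c1cc(Oc2ccc(NC(=O)c3cc(-c4ccc(C)cc4)ncn3)cc2)ccn1` gives > 100000 nM (a limit of the assay, not a number)
- Compound 2 `CNC(=O)c1cc(Oc2ccc(NC(=O)c3cc(-c4ccccc4)ncn3)cc2)ccn1` gives 27100 nM
- Compound 3 `CNC(=O)c1cc(Oc2ccc(NC(=O)c3cc(-c4ccc(F)cc4)ncn3)cc2F)ccn1` gives > 100000 nM (a limit of the assay, not a number)

Compound 3 stands at > 100000 nM, which is only a limit, and it sits at the limit of > 100000 nM in this assay, at which 2 of the 3 values shown sit. Compound 4 `CNC(=O)c1cc(Oc2ccc(NC(=O)c3cc(-c4ccc(F)cc4)ncn3)cc2)ccn1` has not yet been measured in this assay. It differs from compound 3 by one change, (hydrogen in place of fluoro on an aromatic carbon), with hydrogen in place of fluoro on an aromatic carbon. Within the data shown here, the only measured step of a similar kind is an at least 3.6-fold lower number from compound 1 to compound 2 (0.56 log units; beyond the scatter), where hydrogen replaces methyl on an aromatic carbon. That step involves a different leaving group, so it is a loose guide. It starts from a limit. It gives a size only from one side. A lower number is nevertheless expected for compound 4, of modest size. The estimated step is an at least 2.5-fold lower number from compound 3 to compound 4 (0.39 log units; beyond the scatter). For compound 4 the expected value is 40000 nM, with an estimated range from 15000 nM to 100000 nM.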

Compound 4, half-maximal inhibitory concentration: > 100000 nM
Compound 4 was reported as a limit (the forecaster's own chance of this, stated with the estimate: 35%); middle value at least 2.5-fold (0.39 log units) away from the limit.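

In this assay compound 4 gives > 100000 nM, which is a limit of the assay. Removing the fluoro ortho to the (2-(methylcarbamoyl)pyridin-4-yl)oxy group therefore does not bring a measurable value, and compound 2 remains the only one of the four with a number. Fluoro in place of hydrogen on an aromatic carbon gives an at least 3.6-fold higher number from compound 2 to compound 4 (0.56 log units; beyond the scatter), so this change, like the methyl of compound 1, goes with a limit rather than a number; the steps from compound 3 to compound 4 and from compound 1 to compound 4 cannot be read, because both ends of each are limits: the limit of > 100000 nM in this assay, at which 3 of the 4 values shown sit.

Going by these compounds, how far compound 1, compound 3 and compound 4 lie beyond that limit stays open. So does whether a chloro or methoxy group in place of the hydrogen of compound 2 would also give a limit.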